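Adding a methyl to compound 3: what to expect

The compounds below may be only part of what the source reports. "The series", "measured", "known", "first", "only" and "open" are said of these compounds alone.

Compound 1 `NC(=O)c1cn([C@@H]2O[C@H](CO)[C@@H](O)[C@H]2O)nn1`: in a functional assay on CCRF-CEM cells (Homo sapiens) (on this read-out higher numbers stand for weaker inhibition and lower numbers for stronger inhibition), compound 1 gives > 200000 nM, which is a limit of the assay and not a number.
Compound 2 `CCCCCCc1cn([C@@H]2O[C@H](CO)[C@@H](O)[C@H]2O)nn1`: in this assay compound 2 gives > 200000 nM, again only a limit.
Compound 3 `OCc1cn([C@@H]2O[C@H](CO)[C@@H](O)[C@H]2O)nn1`: in this assay compound 3 gives > 200000 nM, also a limit.

Compound 3 therefore stands nowhere in particular among the numbers shown: all three compounds sit at the limit of > 200000 nM in this assay, at which 3 of the 3 values shown sit, so no measurable inhibition has appeared for any of them. The three steps between them, a step that the two limits leave unreadable from compound 1 to compound 2, a step that the two limits leave unreadable from compound 1 to compound 3 and a step that the two limits leave unreadable from compound 2 to compound 3, all remain unreadable in size, because each of them starts and ends at the limit of > 200000 nM in this assay, at which 3 of the 3 values shown sit. Compound 4 `CC(O)c1cn([C@@H]2O[C@H](CO)[C@@H](O)[C@H]2O)nn1` differs from compound 3 by methyl in place of hydrogen on a saturated chain carbon bound to an aromatic carbon and an oxygen on a saturated carbon. The measured steps bear on this change only in showing that larger swaps at the same position left the read-out at the limit. The step that the limit leaves unreadable from compound 3 to compound 4 is thus expected to be nothing that the assay can read. For compound 4 the estimate in this assay is 300000 nM, with a range from 100000 nM to 2000000 nM, most likely reported again as a limit.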

Compound 4, half-maximal inhibitory concentration: > 200000 nM
Compound 4 ended at the assay's limit; the forecaster's own chance of this, stated with the estimate: 85%; the middle value lies beyond the limit too.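

Among these compounds, no step from compound 1, compound 2 or compound 3 to compound 4 can be read, because all four compounds sit at the same limit: the limit of > 200000 nM in this assay, at which 4 of the 4 values shown sit.

In this assay the compounds shown leave open which change to the shared core, if any, would bring measurable inhibition.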